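Ethoxy gives way to (2-fluorobenzyl)oxy on the shared core

The compounds below may be only part of what the source reports. "The series", "measured", "known", "first", "only" and "open" are said of these compounds alone.

Measured so far in an ADME assay on KB cells (Homo sapiens) for cytotoxicity; on this read-out higher numbers stand for an effect only at larger amounts of compound and lower numbers for an effect already at smaller amounts:
Compound 1 `CCOc1c(OC)c(OC)cc2c1C(=O)[C@]1(OC)C=C[C@H]2N(C(=O)OCC(C)C)N1C(=O)OCC(C)C`: > 300 ug/mL (a limit)
Compound 2 `COC(=O)N1[C@@H]2C=C[C@@](OC)(C(=O)c3c2cc(OC)c(OC)c3OCc2ccc(OC)cc2)N1C(=O)OC`: > 300 ug/mL (a limit)
Compound 3 `CCOC(=O)N1[C@@H]2C=C[C@@](OC)(C(=O)c3c2cc(OC)c(OC)c3OCc2ccccc2F)N1C(=O)OCC`: 99.7 ug/mL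

Compound 1 gives no number, only (the limit of > 300 ug/mL in this assay, at which 2 of the 3 values shown sit). Compound 4 `COc1cc2c(c(OCc3ccccc3F)c1OC)C(=O)[C@]1(OC)C=C[C@H]2N(C(=O)OCC(C)C)N1C(=O)OCC(C)C` differs from it in one place, (2-fluorophenyl in place of methyl on a saturated chain carbon bound to an oxygen on an aromatic ring), with 2-fluorophenyl in place of methyl on a saturated chain carbon bound to an oxygen on an aromatic ring. Among the compounds with values here, no measured pair shows this change alone. Compound 3 also carries a 2-fluorobenzyl, though with other chains elsewhere, and gives 99.7 ug/mL, so a move towards lower numbers in this assay is expected. The estimated step is an at least 2.3-fold lower number from compound 1 to compound 4 (0.36 log units; beyond the scatter). For compound 4 the estimated value is 130 ug/mL, with an expected range from 40 ug/mL to 320 ug/mL.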

Compound 4, concentration for half-maximal effect: 109 ug/mL
The estimate for compound 4 lay 1.2-fold (0.08 log units) above the measured number, within the range that was stated.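

Within the data shown here, on the shared core, replacing ethoxy with (2-fluorobenzyl)oxy gives the first step that can be read at this position in this assay, and it runs towards lower numbers: an at least 2.7-fold lower number from compound 1 to compound 4 (0.43 log units; beyond the scatter). So 2-fluorophenyl in place of methyl on this saturated chain carbon bound to an oxygen on an aromatic ring is enough on its own to bring a measurable number. The true size of the step stays unknown, since the starting point is a limit rather than a number: the limit of > 300 ug/mL in this assay, at which 2 of the 4 values shown sit.

The compounds shown leave open how an unsubstituted benzyl or a 3-fluorobenzyl would read at this place. They also leave open whether the fluorine or the phenyl ring itself carries the step.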